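Swapping 4-Chlorophenyl for 2-Chlorophenyl on a Carbonyl Carbon

This account rests on a few compounds, and the source may have more. Where it says the series, first, only, none or still open, it means among the compounds named here.

Measured so far:
- compound 1, `O=C(Nc1ccccc1)C1CCc2ccccc2N1`: 109000 nM
- compound 2, `O=C(Nc1cc(C(F)(F)F)cc(C(F)(F)F)c1)C1CCc2ccccc2N1C(=O)c1ccc(Cl)cc1`: 2220 nM

Both compounds were tested in a functional assay on HCT-15 cells (Homo sapiens) for cytotoxicity, read by sulforhodamine B assay, with a stated time of 72 h; on this read-out lower numbers stand for stronger inhibition of growth and higher numbers for weaker inhibition of growth. In this assay compound 1 gives 109000 nM, while compound 2 gives 2220 nM. Compound 2 therefore holds the lowest number of the two, and the gap to compound 1 lies beyond the usual scatter of repeated measurements. Within the data shown here, since the two differ in more than one place, the comparison shows only that compound 2 is the stronger growth inhibitor of the pair; it does not say which part of the structure carries the difference.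

The next compound, compound 3, is `O=C(Nc1cc(C(F)(F)F)cc(C(F)(F)F)c1)C1CCc2ccccc2N1C(=O)c1ccccc1Cl`. It keeps every atom of compound 2 and changes only how the chlorine-bearing ring is joined: 2-chlorophenyl in place of 4-chlorophenyl on a carbonyl carbon. With no measured pair of this kind in hand, the size of the step is open. The expected change from compound 2 to compound 3 is a 1.6-fold higher number from compound 2 to compound 3 (0.20 log units; within the scatter), at most a small shift and possibly none beyond the scatter. For compound 3 in this assay the estimate is 3500 nM, within a range from 1000 nM to 12000 nM.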

Compound 3, concentration for 50% growth inhibition: 4050 nM
Beside the measured number, compound 3's estimate is 1.2-fold (0.06 log units) below it, within the range that was stated.
By their numbers in this assay, from the lowest: compounds 2 and 3 (each within the scatter of the next); then compound 1.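

In this assay, 2-chlorophenyl in place of 4-chlorophenyl on a carbonyl carbon gives a 1.8-fold higher number from compound 2 to compound 3 (0.26 log units; within the scatter), so on this read-out the two compounds cannot be told apart. Among these compounds, this is the first comparison here that changes a single place, and it shows that, for this one pair, joining the chlorine-bearing ring differently leaves the growth-inhibition number within the scatter, although the atoms of the group stay the same and only their arrangement changes. Nothing measured here bears on what lies behind this result.

On these data alone, this single pair covers only a chlorine on a phenyl ring, so it remains open whether the same position would respond to a larger change, such as a methoxy group, an amine or a carboxylic acid in place of the chlorine, or a plain phenyl without any such group. The large gap that separates compound 1 from compound 2 also remains unassigned, since those two differ in more than one place and neither the trifluoromethyl groups nor the chlorophenyl carbonyl can yet be credited with it.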